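Ester in Place of Thioether on a Shared Amide Core

The compounds below may be only part of what the source reports. "The series", "measured", "known", "first", "only" and "open" are said of these compounds alone.

Compound 1 `O=C(Nc1cccc(N2CCCC2=O)c1)C1CCCN(C(=O)c2cc(C(F)(F)F)cc(C(F)(F)F)c2)C1` and compound 2 `CSc1cccc(NC(=O)C2CCCN(C(=O)c3cc(C(F)(F)F)cc(C(F)(F)F)c3)C2)c1` share one core and differ only in the group on an aromatic carbon. In an ADME assay on PC-3 cells (Homo sapiens) for cytotoxicity, read by WST assay, tested at 100 uM (a lower number here means less inhibition, a higher number more inhibition at the concentration tested (going by the name of the read-out)), compound 1 gives 0%. Compound 2 gives 0% in this assay, so the step of no change at the digits printed from compound 1 to compound 2 (within the scatter) is flat. Compound 2 therefore stands level with compound 1 at the digits shown, and both sit at the bottom of the read-out.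

Compound 3 `COC(=O)c1cccc(NC(=O)C2CCCN(C(=O)c3cc(C(F)(F)F)cc(C(F)(F)F)c3)C2)c1` is the next member and carries a different group on that same core: methoxycarbonyl in place of methylsulfanyl on an aromatic carbon. Within the data shown here, the only measured step that bears on this change is no change at the digits printed from compound 1 to compound 2 (within the scatter), which swapped a group on an aromatic carbon of the same ring without moving the read-out beyond the scatter. Since that step was flat, no step beyond the scatter in either direction is expected here; the expected change is no change at the digits printed from compound 2 to compound 3 (within the scatter). Compound 3 is accordingly estimated to give 0%, within 0% to 12%, in this assay.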

Compound 3, a percentage reported as inhibition, at one concentration (the size of the read-out at that concentration, not a potency): 0%
Beside the measured number, compound 3's estimate shows no gap at the digits printed, and the stated range covers the measured number.
By their numbers in this assay, from the lowest: compounds 1, 2 and 3 (each within the scatter of the next).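

In this assay, the exchange of methylsulfanyl for methoxycarbonyl gives no change at the digits printed from compound 2 to compound 3 (within the scatter), even though the entering group has 4 heavy atoms against 2, a double bond outside aromatic rings and 2 hydrogen-bond acceptors against 1. The exchange of 2-oxopyrrolidin-1-yl for methoxycarbonyl gives no change at the digits printed from compound 1 to compound 3 (within the scatter), so a group without a ring reads the same here as the ring-bearing group of compound 1. This place on the six-membered aromatic ring, meta to a large group, has now carried three different groups, and all three compounds sit at the bottom of the read-out, which extends the flat result of the earlier pair to a group containing a carbonyl.

No measurement shown accounts for this flat result.

With all three compounds at the same bottom value, the series cannot show whether any group at this place would raise the inhibition at the concentration tested. Going by these compounds, it remains open whether an amine, a carboxylic acid or a longer carbon chain on this aromatic carbon would move the read-out, and whether the other parts of the shared core would do so.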